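The source may report more compounds than this note shows. Statements on the series, on what has been measured and on what is new or still open speak of the compounds shown alone.

Measured compounds:
- compound 1, `COc1cc(C)cc(-c2c(-c3ccnc(-c4ccc(C(C)=O)cc4)c3)cnn2CC#N)c1`; in a functional assay on UACC-257 cells (Homo sapiens) for inhibition, read by sulforhodamine B assay, with a stated time of 48 h (a lower number here means a stronger inhibitor of growth, a higher number a weaker inhibitor of growth), compound 1 gives > 100000 nM, which is a limit of the assay and not a number.
- compound 2, `COc1cc(C)cc(-c2nn(CC#N)cc2-c2ccc(-c3cccc(C(C)=O)c3)nc2)c1`; in this assay compound 2 gives > 100000 nM, again a limit.
- compound 3, `Cc1cc(O)cc(-c2nn(CC#N)cc2-c2ccnc(-c3ccc(N(C)C)cc3)c2)c1`; in this assay compound 3 gives 35600 nM.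

Compound 1 stands at the limit of this assay: the limit of > 100000 nM in this assay, at which 2 of the 3 values shown sit. Among the measured compounds shown here, only compound 3 yields a number; compound 3 is the one measured compound that carries dimethylamino. For the measured compounds named here, no step between two measured compounds differing in one place is available, so no measured size can be quoted.

Compound 4, `COc1cc(C)cc(-c2c(-c3ccnc(-c4ccc(N(C)C)cc4)c3)cnn2CC#N)c1`, is reached from compound 1 by one change, (dimethylamino in place of acetyl on an aromatic carbon). The expectation rests on compound 3 alone, because compound 3 gives 35600 nM with the same dimethylamino group in place. Compound 4 is therefore expected to move off the limit into weak but measurable growth inhibition, the expected step being an at least 2.0-fold lower number from compound 1 to compound 4 (0.30 log units; that floor lies within the scatter). The estimate for compound 4 is 50000 nM, within a range from 20000 nM to 150000 nM, with a real chance that this assay again reports only a limit.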

Compound 4, concentration for total growth inhibition: > 100000 nM
Compound 4 gave a limit, no number (the forecaster's own chance of this, stated with the estimate: 40%); middle value at least 2.0-fold (0.30 log units) away from the limit.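

No step can be read from compound 1 to compound 4, because both stand at a limit and not at a number: the limit of > 100000 nM in this assay, at which 3 of the 4 values shown sit.

The compounds shown leave open whether dimethylamino in place of acetyl changes growth inhibition at all on the core of compound 1, and which feature of compound 3 goes with its measurable value.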